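The source may report more compounds than this note shows. Statements on the series, on what has been measured and on what is new or still open speak of the compounds shown alone.

Measured compounds and their values:

compound 1 `COc1ccc(N=C2NC(=O)/C(=C\c3ccc(N(C)C)cc3)S2)cc1`: 2520 nM
compound 2 `CC(=O)Nc1ccc(/C=C2/S/C(=N/c3cccc(Cl)c3)NC2=O)cc1`: 1190 nM
compound 3 `CN(C)c1ccc(/C=C2/S/C(=N/c3ccc(Cl)cc3)NC2=O)cc1`: 2890 nM

All three numbers come from a functional assay on NCI-H460 cells (Homo sapiens) for antiproliferative activity; on this read-out higher numbers stand for weaker inhibition and lower numbers for stronger inhibition. Among them compound 1 sits at the second highest of the three. Compound 3 is its nearest neighbour, and the gap between compound 1 and compound 3 lies within the scatter, so the two cannot be told apart. Compound 2 is the furthest, and its lower number lies beyond the scatter, so compound 2 is the one that stands apart on this read-out.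

The unmeasured compound 4 `CN(C)c1ccc(/C=C2/SC(=Nc3ccccc3Cl)NC2=O)cc1` is compound 1 with one change: 2-chlorophenyl in place of 4-methoxyphenyl on a double-bonded nitrogen. Compound 3 already shows a chlorophenyl on the same nitrogen, and its value against compound 1 lies within the scatter. Among the compounds with values here, compound 2 carries another chlorophenyl there, though with a different group on the other side of the shared core, and is the one with the lower number. Within the data shown here, no direct step between measured compounds is known for this change, so the expectation rests on those values alone.

For compound 4 the estimated number is 2500 nM, with a range from 1000 nM to 6000 nM. The expected step in this assay from compound 1 to compound 4 is a 1.0-fold lower number from compound 1 to compound 4 (0.00 log units; within the scatter), which is estimated to be no change beyond the scatter.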

Compound 4, half-maximal inhibitory concentration: 730 nM
Compound 4: middle estimate off by 3.4-fold (0.53 log units), on the high side, outside the stated range (below it).
By their numbers in this assay, from the lowest: compounds 4 and 2 (each within the scatter of the next); then compounds 1 and 3 (each within the scatter of the next).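

In this assay the replacement of 4-methoxyphenyl by 2-chlorophenyl on the double-bonded nitrogen gives a 3.5-fold lower number from compound 1 to compound 4 (0.54 log units; beyond the scatter) and so shows that a change at this position can move the number beyond the scatter, which the comparison of compound 1 with compound 3 had not shown. Having a chlorophenyl at this nitrogen does not by itself bring the number down: compound 3, with a different chlorophenyl there, gives 2890 nM while compound 4 gives 730 nM in the same assay, so the form of the chlorophenyl group matters in this pair. No measurement shown here offers an explanation for this step.

The compounds shown leave open whether the lower number needs chlorine at all, since 2-fluorophenyl, 2-methylphenyl, 2-methoxyphenyl or plain phenyl on the same nitrogen would be needed to separate the effect of the atom from that of its place on the ring. They also leave open whether the same replacement lowers the number when the dimethylamino group on the other side of the shared core gives way to another group, such as an acetamide.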